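The source may hold more compounds than are shown below. What is called first, only, known or untested is meant among the compounds shown, and "the series" means these compounds.

Measured so far in a functional assay on MCF7 cells (Homo sapiens) for cytotoxicity, read by MTT assay, with a stated time of 72 h; a higher number here means a weaker inhibitor, a lower number a stronger inhibitor:
compound 1, `COc1ccc(/C(=C(/CCNC(=O)NCc2ccccc2)c2ccccc2)c2ccccc2)cc1`: > 50000 nM
compound 2, `CCN(CC)C(=O)NCC/C(=C(\c1ccccc1)c1ccc(OC)cc1)c1ccccc1`: > 50000 nM

In this assay compound 1 gives > 50000 nM, which is a limit of the assay and not a number. In this assay compound 2 gives > 50000 nM, likewise a limit of the assay. Compound 2 therefore stands at the limit, with no number to place it on either side of compound 1. Among the measured compounds shown here, the one measured step, a step that the two limits leave unreadable from compound 1 to compound 2, is unreadable because both values sit at the limit of > 50000 nM in this assay, at which 2 of the 2 values shown sit.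

Compound 3, `COc1ccc(/C(=C(/CCNC(=O)N2CCCCC2)c2ccccc2)c2ccccc2)cc1`, differs from compound 2 by piperidin-1-yl in place of diethylamino on a carbonyl carbon. For the measured compounds named here, the only step that bears on this position is a step that the two limits leave unreadable from compound 1 to compound 2, and it supplies no size to carry over. With both neighbouring values at the limit, the expected step that the limit leaves unreadable from compound 2 to compound 3 from compound 2 to compound 3 is none beyond the scatter, in no readable direction. Compound 3 is therefore estimated at 60000 nM, within a range of 25000 nM to 200000 nM, and is expected most likely to be reported again only as a limit of this assay.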

Compound 3, half-maximal inhibitory concentration: > 50000 nM
Compound 3: a limit, no number; the forecaster's own chance of this, stated with the estimate: 85%; the middle value lies beyond the limit too.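

No step from compound 3 to compound 1 or compound 2 can be read, because all three values are limits and not numbers: the limit of > 50000 nM in this assay, at which 3 of the 3 values shown sit.

The compounds shown leave open how benzylamino, diethylamino and piperidin-1-yl on the carbonyl carbon rank against one another, and whether any group at that place on the shared core gives a readable number.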